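The source may hold more compounds than are shown below. What is called first, only, known or untested is meant among the compounds shown, and "the series" means these compounds.

Compound 2 `CC1=C(C(=O)Nc2ccc([N+](=O)[O-])cc2)C(c2cccc([N+](=O)[O-])c2)N=C(SCc2ccccc2Cl)N1` gives 7.7% in a functional assay on the whole organism (artery, strain albino) with Rattus norvegicus as the target, with a stated time of 120 min, at a dose of 10 mg/kg by the oral route; a lower number here means less inhibition, a higher number more inhibition at the dose given (going by the name of the read-out). For the measured compounds named here, the only other number so far belongs to compound 1 `CC1=C(C(=O)Nc2ccc([N+](=O)[O-])cc2)C(c2cccc([N+](=O)[O-])c2)N=C(SCc2ccccc2)N1`, which gives 10.3% in this assay, and that value lies within the scatter of compound 2's, so the two do not separate. Going by the values given here, the single step between measured compounds, a number 2.6 percentage points lower from compound 1 to compound 2 (within the scatter), is the one that bears here: it put a chloro onto the (2-chlorobenzyl)sulfanyl side of the molecule and stayed within the scatter. Compound 3 `CC1=C(C(=O)Nc2ccc([N+](=O)[O-])cc2)C(c2cccc([N+](=O)[O-])c2)N=C(SCc2ccc(Cl)cc2)N1` has not been measured in this assay. It differs from compound 2 by 4-chlorophenyl in place of 2-chlorophenyl on a saturated chain carbon bound to a sulfur. Since the step from compound 1 to compound 2 was small, no step beyond the scatter is expected for compound 3, and its estimated step of a number 1.3 percentage points higher from compound 2 to compound 3 (within the scatter) is accordingly small. Compound 3 is therefore expected to give about 9% in this assay, with a range from 0% to 22%.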

Compound 3, a percentage reported as inhibition, in the whole organism at one dose (the size of the read-out at that dose, not a potency): 12.4%
Compound 3: middle estimate off by 3.4 percentage points, on the low side; low and high end bracket the measured number.
By their numbers in this assay, from the lowest: compounds 2, 1 and 3 (each within the scatter of the next).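

Moving the chlorine from 2-chlorobenzyl to 4-chlorobenzyl gives a number 4.7 percentage points higher from compound 2 to compound 3 (within the scatter) in this assay, and the 4-chlorobenzyl group in place of plain benzyl gives a number 2.1 percentage points higher from compound 1 to compound 3 (within the scatter). At this position, then, neither the presence of a chloro on the benzyl group nor its place on the ring separates the three compounds at this dose. Nothing measured here offers a reason for these small differences.

Still open, going by these compounds, is whether a different group on this benzyl, such as methoxy or an amine, or a longer chain on the sulfur, would move the number beyond the scatter. The two nitro groups and the amide are the same in all three compounds, so what they contribute to the inhibition cannot be told.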